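Methylating the Ring Nitrogen of Compound 2

The source may report more compounds than this note shows. Statements on the series, on what has been measured and on what is new or still open speak of the compounds shown alone.

Compound 2 `CNC(=O)/C=C/c1ccncc1-c1ccc2[nH]ccc2c1` gives 51.9 nM in an assay on a protein complex for inhibition of CDK8/Cyclin C (Homo sapiens), with a stated time of 1 h (on this read-out lower numbers stand for stronger inhibition and higher numbers for weaker inhibition), the second highest of three numbers. Among the measured compounds shown here, compound 1 `Cn1ccc2cc(-c3cnccc3/C=C/C(=O)O)ccc21` gives 26.8 nM and compound 3 `O=C(/C=C/c1ccncc1-c1ccc2[nH]ccc2c1)N1CCOCC1` gives 190 nM; the only single change measured so far is a 3.7-fold higher number from compound 2 to compound 3 (0.56 log units; beyond the scatter). Compound 4 `CNC(=O)/C=C/c1ccncc1-c1ccc2c(ccn2C)c1` differs from compound 2 by methyl in place of hydrogen on an aromatic nitrogen. For the measured compounds named here, no measured step covers this change: compound 1 differs from compound 2 in two places at once, and its number sits within the scatter of that of compound 2, while the step to compound 3 concerns the carbonyl carbon. With nothing pointing either way, the expected step is a 1.0-fold lower number from compound 2 to compound 4 (0.02 log units; within the scatter). Compound 4 is therefore estimated at 50 nM, between 20 nM and 130 nM.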

Compound 4, half-maximal inhibitory concentration: 77.6 nM
Beside the measured number, compound 4's estimate is 1.6-fold (0.19 log units) below it, and the stated range covers the measured number.
By their numbers in this assay, from the lowest: compounds 1, 2 and 4 (each within the scatter of the next, the first and the last beyond it); then compound 3.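

In this assay putting methyl in place of hydrogen on the aromatic nitrogen gives a 1.5-fold higher number from compound 2 to compound 4 (0.17 log units; within the scatter) and so, in this pair, the read-out does not depend on that hydrogen. The carbonyl carbon is different: methylamino in place of hydroxy gives a 2.9-fold higher number from compound 1 to compound 4 (0.46 log units; beyond the scatter) and this is the second change there to go beyond the scatter, after morpholin-4-yl. Nothing here explains either step. Still open, as far as these compounds go, is whether ethyl or a longer chain on that nitrogen would stay within the scatter, and how a primary amide at the carbonyl carbon would compare.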